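The source may report more compounds than this note shows. Statements on the series, on what has been measured and on what is new or still open speak of the compounds shown alone.

Compound 2 `CCCSc1nc(Cl)c2c(n1)N(Cc1ccccc1)C(C(=O)N1CCN(C)CC1)N2` is a cousin of compound 1 `CCCSc1nc(Cl)c2c(n1)N(Cc1ccccc1)C(C(=O)O)N2`; the two share a core and differ only in what hangs on a carbonyl carbon. In a functional assay on PC-3 cells (Homo sapiens) for antiproliferative activity, read by MTT assay, with a stated time of 72 h (a lower number here means a stronger inhibitor, a higher number a weaker inhibitor), compound 1 gives 49200 nM, and compound 2 gives 29800 nM. Among the measured compounds shown here, of the two numbers so far, compound 2 has the lower one, yet the step of a 1.7-fold lower number from compound 1 to compound 2 (0.22 log units; within the scatter) means the pair cannot be told apart with confidence.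

Compound 3 `CCCSc1nc(Cl)c2c(n1)N(Cc1ccccc1)C(C(=O)NCC(C)C)N2` takes the next step: isobutylamino in place of 4-methylpiperazin-1-yl on a carbonyl carbon. For the measured compounds named here, the only measured step that touches this carbonyl carbon, a 1.7-fold lower number from compound 1 to compound 2 (0.22 log units; within the scatter), stayed within the scatter, so the data give no sign that changes at this spot move the number much. The expected step of a 1.2-fold lower number from compound 2 to compound 3 (0.08 log units; within the scatter) in this assay is therefore no step beyond the scatter. Compound 3 is estimated at 25000 nM, with a likely range from 8000 nM to 80000 nM.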

Compound 3, half-maximal inhibitory concentration: > 64000 nM
Compound 3 ended at the assay's limit; the forecaster's own chance of this, stated with the estimate: 15%; middle value at least 2.5-fold (0.40 log units) from the limit.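

In this assay, compound 3 carries a limit of the assay and not a number: the limit of > 64000 nM in this assay, at which 1 of the 3 values shown sits.

Even so, this is the first change on the carbonyl carbon to clear the scatter, with an at least 2.1-fold higher number from compound 2 to compound 3 (0.33 log units; beyond the scatter), so the group here can move the number when isobutylamino replaces 4-methylpiperazin-1-yl. The comparison with hydroxy is less firm, with an at least 1.3-fold higher number from compound 1 to compound 3 (0.11 log units; that floor lies within the scatter), so this floor alone does not separate the isobutylamino amide from the acid.

Going by these compounds, the true size of both steps stays unknown, since only a floor is available for each. Also open, on these data alone, is whether a morpholine ring, an unsubstituted piperazine or a longer chain on this carbonyl carbon would read closer to compound 2 or to compound 3.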